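Swapping naphthalen-1-yl for 4-methoxyphenyl in compound 2

This account rests on a few compounds, and the source may have more. Where it says the series, first, only, none or still open, it means among the compounds named here.

Measured in a functional assay on THP-1 cells (Homo sapiens) for inhibition, read by sulforhodamine B assay, with a stated time of 48 h, tested at 50 uM; on this read-out lower numbers stand for less inhibition of growth and higher numbers for more inhibition of growth at the one concentration tested:
- compound 1 `COc1ccc(/C=C/C(=O)/C=C/c2ccc(OCc3cn(CCCCCOc4cc(=O)oc5ccccc45)nn3)c(OC)c2)cc1OC`: 47%
- compound 2 `COc1cc(/C=C/C(=O)/C=C/c2cccc3ccccc23)ccc1OCc1cn(CCCCCOc2cc(=O)oc3ccccc23)nn1`: 44%
- compound 3 `COc1cccc(/C=C/C(=O)/C=C/c2ccc(OCc3cn(CCOc4cc(=O)oc5ccccc45)nn3)c(OC)c2)c1`: 77%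

In this assay, compound 2 gives 44%. That places it level with compound 1, within the usual scatter, while compound 3 stands well clear of both at 77%.

The next compound to consider is compound 4 `COc1ccc(/C=C/C(=O)/C=C/c2ccc(OCc3cn(CCCCCOc4cc(=O)oc5ccccc45)nn3)c(OC)c2)cc1`, which keeps everything in compound 2 except one group: 4-methoxyphenyl in place of naphthalen-1-yl on a double-bonded chain carbon bound to a double-bonded chain carbon.

Among the measured compounds shown here, only one measured step bears directly on this change. Replacing 3,4-dimethoxyphenyl with naphthalen-1-yl at the same place gave a number 3 percentage points lower from compound 1 to compound 2 (within the scatter). Compound 3 differs from compound 2 in more than one place, so its higher value cannot be assigned to this group. For the measured compounds named here, the single step is thin evidence, but it offers no reason to expect a large move when another substituted phenyl group enters at this place. The step expected here is a number 2 percentage points higher from compound 2 to compound 4 (within the scatter), an estimate that stays within the scatter and has no firm direction. Compound 4 is expected to give 46%, with an estimated range of 34% to 58%.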

Compound 4, percent growth inhibition at one concentration: 39%
For compound 4 the middle estimate is 7 percentage points above the measured one; the range from low to high includes it.
By their numbers in this assay, from the lowest: compounds 4, 2 and 1 (each within the scatter of the next); then compound 3.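

In this assay, the change at this place from naphthalen-1-yl to 4-methoxyphenyl gave a number 5 percentage points lower from compound 2 to compound 4 (within the scatter) and so left the read-out within the scatter, even though the entering group has one aromatic ring in place of two and brings one hydrogen-bond acceptor. Taking the methoxy off the 3,4-dimethoxyphenyl group, a change the earlier compounds did not cover, gave a number 8 percentage points lower from compound 1 to compound 4 (within the scatter) and so likewise showed no clear effect, which means that compounds 1, 2 and 4, with their three different aryl groups on a double-bonded chain carbon, cannot be told apart at the one concentration tested. Nothing in the available data offers an explanation for how little these changes register.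

Compound 3 at 77% differs from each of these compounds in more than one place, so the source of its higher number stays unresolved, and a compound that changes only the pentyl-length chain would be needed to separate the chain from the aryl group. From the compounds shown here alone, it also remains open whether this place would respond to a group of another kind, such as a phenyl ring carrying a dimethylamino group or a carboxylic acid.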